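Swapping a ring for an amine chain on the piperazine

The source may report more compounds than this note shows. Statements on the series, on what has been measured and on what is new or still open speak of the compounds shown alone.

Measured so far:
compound 1, `Cc1cccc2sc(NC(=O)CCN3CCN(C(C)(C)C)CC3)nc12`, gives 147 nM in an assay on membranes from brain for displacement of a labelled ligand from Sigma non-opioid intracellular receptor 1 (Cavia porcellus), read by scintillation counting, with a stated time of 120 min; on this read-out higher numbers stand for weaker inhibition and lower numbers for stronger inhibition;
compound 2, `Cc1cccc2sc(NC(=O)CCN3CCN(CCCN(C)C)CC3)nc12`, gives 570 nM in this assay;
compound 3, `Cc1cccc2sc(NC(=O)CCN3CCN(CC4CCCO4)CC3)nc12`, gives 109 nM in this assay.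

Compound 3 has the lowest number of the three, but a 1.3-fold lower number from compound 1 to compound 3 (0.13 log units; within the scatter) is within the scatter, so compound 1 and compound 3 cannot be ordered. Only compound 2 stands apart: a 5.2-fold lower number from compound 2 to compound 3 (0.72 log units; beyond the scatter).

Compound 4, `Cc1cccc2sc(NC(=O)CCN3CCN(CCN(C(C)C)C(C)C)CC3)nc12`, differs from compound 3 in one place: (diisopropylamino)methyl in place of oxolan-2-yl on a saturated chain carbon bound to an amine nitrogen in a ring. Cut one bond further out, this reads (oxolan-2-yl)methyl to 2-(diisopropylamino)ethyl. Among the measured compounds shown here, the step that bears on this is the one from compound 2 to compound 3, where a 2-(dimethylamino)ethyl gave way to oxolan-2-yl and the number fell by a 5.2-fold lower number from compound 2 to compound 3 (0.72 log units; beyond the scatter). For the measured compounds named here, compound 4 runs that change backwards, though with diisopropylamino in place of dimethylamino, so a higher number than compound 3 is expected, of modest size, with much uncertainty since no measured compound carries diisopropylamino.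

The expected step from compound 3 to compound 4 is a 3.2-fold higher number from compound 3 to compound 4 (0.51 log units; beyond the scatter). Compound 4 is therefore estimated at 350 nM, within a range from 120 nM to 1000 nM.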

Compound 4, inhibition constant: 809 nM
The estimate for compound 4 lay 2.3-fold (0.36 log units) below the measured number; the measured number falls inside the stated range.
By their numbers in this assay, from the lowest: compounds 3 and 1 (each within the scatter of the next); then compounds 2 and 4 (each within the scatter of the next).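

In this assay, the new result places compound 4 with compound 2 rather than with the other two: the change from 3-(dimethylamino)propyl to 2-(diisopropylamino)ethyl on the same ring nitrogen gives (a 1.4-fold higher number from compound 2 to compound 4 (0.15 log units; within the scatter)), so these two compounds cannot be ordered. Compound 4 also separates from both compounds without a second amine, as the change from (oxolan-2-yl)methyl gives (a 7.4-fold higher number from compound 3 to compound 4 (0.87 log units; beyond the scatter)) and the change from tert-butyl gives (a 5.5-fold higher number from compound 1 to compound 4 (0.74 log units; beyond the scatter)), so among these four compounds, with none going against it, both groups that end in an amine carry higher numbers than the two groups that do not. Nothing shown here explains this split.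

Chain length and the groups on the end nitrogen change together from compound 2 to compound 4, so the compounds shown leave open what each contributes, and a 2-(dimethylamino)ethyl group on the ring nitrogen would help to separate them. From the compounds shown here alone, it also remains open whether the ring of the (oxolan-2-yl)methyl group matters, which an open-chain ether such as 2-methoxyethyl could test.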